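A few compounds are considered here, and "the series" means these few. Any claim that something is new, unique, unknown or untested is made for them only; others in the source may bear on it.

Compound 1, `Nc1scc(CN2CCN(c3ccc(Cl)c(C(F)(F)F)c3)CC2)c1C(=O)c1ccc(Cl)cc1`, is the starting point. In an assay on CHO cells for displacement of a labelled ligand from adenosine receptor A3 (Homo sapiens), read by scintillation counting, with a stated time of 120 min, tested at 10 uM (a lower number here means less inhibition, a higher number more inhibition at the concentration tested (going by the name of the read-out)), compound 1 gives 3%. Two companions share its core and differ only in the aryl group on the ring nitrogen: compound 2, `Nc1scc(CN2CCN(c3ccccc3F)CC2)c1C(=O)c1ccc(Cl)cc1`, gives 0% in this assay, and compound 3, `Nc1scc(CN2CCN(c3ccc(F)cc3F)CC2)c1C(=O)c1ccc(Cl)cc1`, gives 0%. On the numbers shown compound 1 stands highest of the three, but the steps of a number 3 percentage points lower from compound 1 to compound 2 (within the scatter) and a number 3 percentage points lower from compound 1 to compound 3 (within the scatter) both lie within the usual scatter, so the three compounds cannot really be told apart; the same holds for compounds 2 and 3, where no change at the digits printed from compound 2 to compound 3 (within the scatter). Compound 4, `Nc1scc(CN2CCN(CCCc3ccc(Cl)cc3)CC2)c1C(=O)c1ccc(Cl)cc1`, has not yet been measured. Its change from compound 1 is 3-(4-chlorophenyl)propyl in place of 4-chloro-3-(trifluoromethyl)phenyl on an amine nitrogen in a ring. Among the measured compounds shown here, the steps that bear on this are the two earlier swaps on the same ring nitrogen, from compound 1 to compound 2 and from compound 1 to compound 3, each within the scatter, and they show that replacing the group on that nitrogen has left the read-out essentially unmoved. The new group in compound 4 is a chain rather than an aromatic ring on that nitrogen, a kind of change the measured set does not cover, but with nothing here rising above the scatter no step beyond it is expected in this assay, and the expected step is a number 1 percentage points lower from compound 1 to compound 4 (within the scatter). Compound 4 is therefore estimated at 2%, within a range from -7% to 11%.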

Compound 4, a percentage reported as inhibition, at one concentration (the size of the read-out at that concentration, not a potency): 0%
The estimate for compound 4 lay 2 percentage points above the measured number; low and high end bracket the measured number.
By their numbers in this assay, from the lowest: compounds 2, 3, 4 and 1 (each within the scatter of the next).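

In this assay, the aromatic ring on the ring nitrogen can now be carried on a propyl chain instead of sitting directly on that nitrogen, with no readable effect on the result: the swap to 3-(4-chlorophenyl)propyl gives a number 3 percentage points lower from compound 1 to compound 4 (within the scatter). Compared with the two fluorinated aryl groups, the chain also makes no readable difference, with no change at the digits printed from compound 3 to compound 4 (within the scatter) and no change at the digits printed from compound 2 to compound 4 (within the scatter). So the four groups tried at this position, three aryl groups and one arylalkyl group, cannot be told apart in this read-out, and nothing here explains why it stays so flat.

Going by these compounds, whether any group on this nitrogen can lift the read-out beyond the scatter remains open, for example a longer chain, or a chain ending in an amine or a carboxylic acid instead of a chlorophenyl ring. Also open, on these data alone, is whether changing another part of the shared core, such as replacing the amino group or the 4-chlorophenyl group on the carbonyl, would move the read-out where these changes on the nitrogen did not.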